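This account rests on a few compounds, and the source may have more. Where it says the series, first, only, none or still open, it means among the compounds named here.

Among the measured compounds shown here, compound 1 `CC(=O)Oc1ccccc1C(=O)O[C@H]1CO[C@H]2[C@@H]1OC[C@H]2OC(=O)c1ccccc1C` gives the lower of the two numbers so far known in an ADME assay on a cell-free system (plasma, Homo sapiens) for metabolic stability, with Plasma (Rattus norvegicus) as the target, read by HPLC, at pH 7.4; a lower number here means that the compound disappears faster, a higher number that the compound lasts longer: in this assay compound 1 gives 0.0138 h, while compound 2 `CC(=O)Nc1cccc(C(=O)O[C@@H]2CO[C@H]3[C@@H]2OC[C@@H]3OC(=O)c2ccccc2OC(C)=O)c1` gives 0.0583 h. For the measured compounds named here, the one measured step, a 4.2-fold higher number from compound 1 to compound 2 (0.63 log units; beyond the scatter), is also the only measured change at the carbonyl carbon in question. Compound 3 `CC(=O)Oc1ccccc1C(=O)O[C@H]1CO[C@H]2[C@@H]1OC[C@H]2OC(=O)c1cnoc1C` differs from compound 1 at that same place: 5-methyl-1,2-oxazol-4-yl in place of 2-methylphenyl on a carbonyl carbon. Going by the values given here, no measured pair shows this particular exchange, so the step from compound 1 to compound 2 is the only guide, and it shows that swapping the group on this carbonyl carbon can shift the half-life beyond the scatter. Among the compounds with values here, the entering group in compound 3 is not the one tried in compound 2, so the direction is uncertain, and only a small rise, a 1.8-fold higher number from compound 1 to compound 3 (0.26 log units; within the scatter), is expected. Compound 3 is therefore estimated at 0.025 h, within 0.008 h to 0.08 h.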

Compound 3, half-life: 0.001 h
Estimate against measurement, compound 3: 25-fold (1.40 log units) above; the measured number lies below the stated range.
By their numbers in this assay, from the lowest: compound 3; then compound 1; then compound 2.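

The exchange of 2-methylphenyl for 5-methyl-1,2-oxazol-4-yl on this carbonyl carbon lowers the number in this assay, with a 14-fold lower number from compound 1 to compound 3 (1.14 log units; beyond the scatter), so a change here can move the half-life down as well as up, and by more than the earlier step showed. Set against 3-acetamidophenyl at the same place, the new group gives a 58-fold lower number from compound 2 to compound 3 (1.77 log units; beyond the scatter), which puts compound 3 lowest of the three, with each step between them beyond the scatter. Nothing given here explains this fall.

Going by these compounds, it remains open whether the fall follows the five-membered aromatic ring with its hetero atoms or the loss of the six-membered ring of carbon. How a pyridin-3-yl or an unsubstituted phenyl group would behave on this carbonyl carbon also stays unanswered.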